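The source may hold more compounds than are shown below. What is called first, only, known or untested is meant among the compounds shown, and "the series" means these compounds.

Compound 3 `C=C1C[C@]23C[C@@]1(O)CC[C@H]2c1ccc(O)c(C)c1[C@@H]3Cn1cc(-c2ccc(F)cc2)nn1` gives in a functional assay on MCF7 cells (Homo sapiens) for cytotoxicity, read by MTT assay, with a stated time of 4 days (a lower number here means a stronger inhibitor, a higher number a weaker inhibitor), only a limit, > 20000 nM. Its measured neighbours frame it: compound 1 `C=C1C[C@]23C[C@@]1(O)CC[C@H]2c1ccc(O)c(C)c1[C@@H]3Cn1cc(-c2ccc(C(F)(F)F)cc2)nn1` gives 12400 nM in this assay, and compound 2 `C=C1C[C@]23C[C@@]1(O)CC[C@H]2c1cc(Br)c(O)c(C)c1[C@@H]3Cn1cc(-c2ccc(F)cc2)nn1` gives 19200 nM. The steps of an at least 1.6-fold higher number from compound 1 to compound 3 (0.20 log units; that floor lies within the scatter) and an at least 1.0-fold higher number from compound 2 to compound 3 (0.01 log units; that floor lies within the scatter) both end at the limit (the limit of > 20000 nM in this assay, at which 1 of the 3 values shown sits), so their true size is unresolved. Compound 4 `C=C1C[C@]23C[C@@]1(O)CC[C@H]2c1ccc(O)c(C)c1[C@@H]3Cn1cc(-c2ccc(Cl)cc2)nn1` differs from compound 3 by chloro in place of fluoro on an aromatic carbon. For the measured compounds named here, the one measured step on the same aromatic carbon, an at least 1.6-fold higher number from compound 1 to compound 3 (0.20 log units; that floor lies within the scatter), points toward a lower number with trifluoromethyl than with fluoro, but its floor sits within the scatter, and no other step bears on this change. For compound 4 a number near the limit is expected, a step of a number no higher from compound 3 to compound 4 (the limit leaves the size open), giving an estimate of 20000 nM with a range from 8000 nM to 50000 nM.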

Compound 4, half-maximal inhibitory concentration: > 20000 nM
Compound 4 gave a limit, no number; the forecaster's own chance of this, stated with the estimate: 50%; the middle value sits exactly at the limit.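

In this assay compound 4 gives > 20000 nM as a limit and not a number, so chloro and fluoro at this position cannot be ordered and the step between them cannot be read. For the compounds shown here, the step of an at least 1.6-fold higher number from compound 1 to compound 4 (0.20 log units; that floor lies within the scatter) separates chloro from trifluoromethyl no better than the step of an at least 1.6-fold higher number from compound 1 to compound 3 (0.20 log units; that floor lies within the scatter) separates fluoro from trifluoromethyl. The limit now covers more of the series: the limit of > 20000 nM in this assay, at which 2 of the 4 values shown sit.

Still open, from the compounds shown here alone, is how far compound 3 and compound 4 lie past the limit. Also open, going by these compounds, is whether an amine or a carboxylic acid at this position would give a readable number.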